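Taking one methyl off compound 2: what to expect

The compounds below may be only part of what the source reports. "The series", "measured", "known", "first", "only" and "open" are said of these compounds alone.

In a functional assay on A549 cells (Homo sapiens) for cytotoxicity, read by MTT assay, with a stated time of 72 h (on this read-out lower numbers stand for stronger inhibition and higher numbers for weaker inhibition), compound 2 `Cn1ccc2c(Oc3ccc(NC(=O)c4cc5cccnc5n(-c5ccc(Br)cc5)c4=O)cc3F)ncnc21` gives 42200 nM, which lies within the scatter of compound 1 `Cn1ccc2c(Oc3ccc(NC(=O)c4cc5cccnc5n(-c5ccc(Br)cc5)c4=O)cc3)ncnc21` at 52200 nM. These two numbers therefore cannot be told apart. The third tested molecule, compound 3 `Cn1ccc2c(Oc3ccc(NC(=O)c4cc5cccnc5n(-c5ccc(C(F)(F)F)cc5Cl)c4=O)cc3F)ncnc21`, is recorded as "not active" (no number reported), so it offers no number for comparison.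

The next molecule, compound 4 `O=C(Nc1ccc(Oc2ncnc3[nH]ccc23)c(F)c1)c1cc2cccnc2n(-c2ccc(Br)cc2)c1=O`, differs from compound 2 by hydrogen in place of methyl on an aromatic nitrogen. Among the compounds with values here, the only measured step is a 1.2-fold lower number from compound 1 to compound 2 (0.09 log units; within the scatter), which comes from fluoro in place of hydrogen on an aromatic carbon. That step is small, but it is a different change at a different place. Within the data shown here, no measured pair shows what happens when this methyl is removed, so the data give only weak guidance and no firm direction.

The estimate is a 1.3-fold lower number from compound 2 to compound 4 (0.11 log units; within the scatter), so no step beyond the scatter is expected in this assay. Compound 4 is expected at about 33000 nM, with an estimated range from 9000 nM to 90000 nM.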

Compound 4, half-maximal inhibitory concentration: 27300 nM
For compound 4 the middle estimate is 1.2-fold (0.08 log units) above the measured one; the measured number falls inside the stated range.
By their numbers in this assay, from the lowest: compounds 4, 2 and 1 (each within the scatter of the next).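

Hydrogen in place of methyl on the aromatic nitrogen gives a 1.5-fold lower number from compound 2 to compound 4 (0.19 log units; within the scatter) in this assay and so adds the first measured step at this position. The methyl on the five-membered aromatic ring can be replaced by hydrogen, leaving a free hydrogen on that nitrogen, without a shift that can be told apart from ordinary repeat-to-repeat variation. No measurement at hand explains this outcome or shows what role the methyl plays here. Going by these compounds, one swap at one position says little about other groups on this nitrogen, so it remains open whether a longer chain such as ethyl or propyl would also leave the number within the scatter. The same question applies to a chain ending in an amine or a carboxylic acid.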